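Ring Opening at the Chain: Cyclopropyl to Isopropyl

This account rests on a few compounds, and the source may have more. Where it says the series, first, only, none or still open, it means among the compounds named here.

Two close analogues have been measured so far. Compound 1, `Brc1cccc2c1nnn2CC1CCC1`, gives 11.4 mL/min/g in an ADME assay on microsomes from liver (Mus musculus, strain NMRI) for metabolic stability, tested at 2.5 uM; on this read-out higher numbers stand for fast clearance and lower numbers for slow clearance. Compound 2, `Brc1cccc2c1nnn2CC1CC1`, gives 7.7 mL/min/g in the same assay. Among the measured compounds shown here, the only change between them is cyclopropyl in place of cyclobutyl on a saturated chain carbon bound to an aromatic nitrogen, and that step, a 1.5-fold lower number from compound 1 to compound 2 (0.17 log units; within the scatter), is small enough that the two compounds cannot be told apart on this read-out. Compound 2 therefore reads as the slower-clearing of the pair only nominally, and the gap to compound 1 is within the scatter.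

Compound 3, `CC(C)Cn1nnc2c(Br)cccc21`, is the next step. Its change from compound 2 is isopropyl in place of cyclopropyl on a saturated chain carbon bound to an aromatic nitrogen. For the measured compounds named here, the only measured step that speaks to this spot on the molecule is the one from compound 1 to compound 2, which swapped one small ring for another at the same position and stayed within the scatter. With no step beyond the scatter in hand, compound 3 is expected to sit close to compound 2, with a 1.0-fold higher number from compound 2 to compound 3 (0.02 log units; within the scatter) as the estimated step. Compound 3 is thus estimated at 8 mL/min/g, in a range from 4 mL/min/g to 16 mL/min/g.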

Compound 3, intrinsic clearance in a liver preparation (reported as CLH), per the amount of preparation that the assay uses: 3.5 mL/min/g
For compound 3 the middle estimate is 2.3-fold (0.36 log units) above the measured one; the whole stated range lies above it.
By their numbers in this assay, from the lowest: compound 3; then compounds 2 and 1 (each within the scatter of the next).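

In this assay this position proves sensitive to more than the swap between two small rings. Opening the ring to give isopropyl, with the count of 3 heavy atoms unchanged, produces a step beyond the scatter (a 2.2-fold lower number from compound 2 to compound 3 (0.34 log units; beyond the scatter)), which the exchange of cyclobutyl for cyclopropyl did not do. The same holds against the cyclobutyl compound (a 3.3-fold lower number from compound 1 to compound 3 (0.51 log units; beyond the scatter)), so compound 3 has the lowest number of the three, and among these compounds the open-chain group stands apart from both ring-bearing groups, while nothing shown here says why the number falls when the ring is opened.

As far as these compounds go, these three compounds cover only small carbon groups on a saturated chain carbon bound to an aromatic nitrogen, so it remains open whether a further branched group such as tert-butyl, or a longer chain such as n-butyl, would keep the number as low as in compound 3. How a group carrying heteroatoms, such as an amine or a carboxylic acid, would behave at this place in this assay is also left open.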